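Lengthening the amine side chain on a ubiquitin hydrolase inhibitor

A few compounds are considered here, and "the series" means these few. Any claim that something is new, unique, unknown or untested is made for them only; others in the source may bear on it.

Measured compounds:
compound 1 `CN(C)Cc1ccc(-c2c3ncn(CC4(O)CCN(Cc5ccc(-c6ccco6)cc5Cl)CC4)c(=O)c3nn2C)cc1` — 131 nM
compound 2 `Cn1nc2c(=O)n(CC3(O)CCN(Cc4ccc(-c5ccco5)cc4Cl)CC3)cnc2c1-c1ccc(C(=N)N)cc1` — 87.5 nM
compound 3 `CCNCc1ccc(-c2c3ncn(CC4(O)CCN(Cc5ccc(-c6ccco6)cc5Cl)CC4)c(=O)c3nn2C)cc1` — 15.2 nM

These three compounds share one core and differ only in the group carried on the outer aromatic ring. In an assay on isolated protein for inhibition of ubiquitin carboxyl-terminal hydrolase 7 (Homo sapiens), with stated times of 30 min and 2 h (a higher number here means a weaker inhibitor, a lower number a stronger inhibitor), compound 3 gives the lowest number of the three: compound 2 sits a 5.8-fold lower number from compound 2 to compound 3 (0.76 log units; beyond the scatter) away, and compound 1 further still, an 8.6-fold lower number from compound 1 to compound 3 (0.94 log units; beyond the scatter). Between compound 1 and compound 2 the gap is a 1.5-fold lower number from compound 1 to compound 2 (0.18 log units; within the scatter).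

Compound 4 `CCCNCc1ccc(-c2c3ncn(CC4(O)CCN(Cc5ccc(-c6ccco6)cc5Cl)CC4)c(=O)c3nn2C)cc1` has not yet been measured. It differs from compound 3 by methyl in place of hydrogen on a saturated chain carbon, two bonds along the chain from an amine nitrogen, so the ethylamino of compound 3 becomes a propylamino. Among the compounds with values here, no measured pair here shows this kind of one-carbon lengthening; the two steps that reach compound 3 exchange the whole amine group, and both are modest in size. Adding a single carbon to an already favourable chain is a much smaller change than either, so no shift beyond the scatter is expected in this assay. Compound 4 is therefore estimated to give a value close to compound 3, 18 nM, with a range from 7 nM to 50 nM, which means an expected step of a 1.2-fold higher number from compound 3 to compound 4 (0.07 log units; within the scatter).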

Compound 4, half-maximal inhibitory concentration: 43.9 nM
Compound 4: middle estimate off by 2.4-fold (0.39 log units), on the low side; the measured number falls inside the stated range.
By their numbers in this assay, from the lowest: compound 3; then compounds 4, 2 and 1 (each within the scatter of the next, the first and the last beyond it).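

One added carbon on the amine chain, turning ethylamino into propylamino, gives a 2.9-fold higher number from compound 3 to compound 4 (0.46 log units; beyond the scatter) in this assay and so shows that this position responds to a single methyl, and that ethylamino is not merely the start of a run in which longer chains do better. Propylamino still keeps an edge over dimethylamino, with a 3.0-fold lower number from compound 1 to compound 4 (0.47 log units; beyond the scatter) on record, while a 2.0-fold lower number from compound 2 to compound 4 (0.30 log units; within the scatter) is too small to place that pair in order. Nothing available here accounts for the effect of this change.

The compounds shown leave open whether a longer straight chain such as butylamino would raise the number further, and whether the shorter methylamino or the branched isopropylamino would do better or worse than ethylamino. Going by these compounds, with ethylamino and propylamino as the only straight chains of this kind on the nitrogen, the shape of any relationship between chain length and the measured number remains unknown.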